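Butoxy extension in a series held at the limit

This account rests on a few compounds, and the source may have more. Where it says the series, first, only, none or still open, it means among the compounds named here.

Values in a functional assay on RAW264.7 cells (Mus musculus) for inhibition, read by Griess assay, with stated times of 1 h and 24 h (on this read-out lower numbers stand for stronger inhibition and higher numbers for weaker inhibition), each one a limit:
- compound 1 `Cc1noc(CC2OC(=O)c3ccccc32)n1`: > 10000 nM
- compound 2 `COc1ccc(C(O)C2OC(=O)c3c(OC)cc(OC)cc32)cc1`: > 10000 nM
- compound 3 `CCOc1ccc(C(O)C2OC(=O)c3c(OC)cc(OC)cc32)cc1`: > 10000 nM

Compound 3 stands at the limit of > 10000 nM in this assay, at which 3 of the 3 values shown sit. It therefore has no number of its own, and the data give no ranking among the three compounds.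

The next compound is compound 4 `CCCCOc1ccc(C(O)C2OC(=O)c3c(OC)cc(OC)cc32)cc1`. The change is ethyl in place of hydrogen on a saturated chain carbon, two bonds along the chain from an oxygen on an aromatic ring, which takes ethoxy to butoxy. Among the compounds with values here, only one measured step bears on it, a change at the same chain: a step that the two limits leave unreadable from compound 2 to compound 3. With no readable size or direction, that step gives no basis for expecting a shift of any particular size or sign in this assay. The expectation is therefore no readable gain in inhibition, and compound 4 will most likely return only a limit again. The step expected on this basis is a step that the limit leaves unreadable from compound 3 to compound 4. The estimate for compound 4 is 20000 nM, with an expected range from 7000 nM to 60000 nM.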

Compound 4, half-maximal inhibitory concentration: 1800 nM
Estimate against measurement, compound 4: 11-fold (1.05 log units) above; measured number below the stated range.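

In this assay, the ethoxy to butoxy change on this chain gives the first readable gain in the alkoxy series: an at least 5.5-fold lower number from compound 3 to compound 4 (0.74 log units; beyond the scatter). Against the methoxy member, the same position gives an at least 5.5-fold lower number from compound 2 to compound 4 (0.74 log units; beyond the scatter), so chain length at this oxygen on the aromatic ring can move the read-out, although both step sizes are bounds set by limits and not exact differences. Butoxy is the only group shown here that brings a compound off the limit: the limit of > 10000 nM in this assay, at which 3 of the 4 values shown sit.

Whether the gain appears gradually or only at butoxy remains open, since propoxy, the intermediate chain, is absent from the compounds shown. On these data alone, it is also open whether a longer chain such as hexyloxy would strengthen inhibition further or reverse it, and whether a terminal amine on the chain would keep the effect.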